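A few compounds are considered here, and "the series" means these few. Any claim that something is new, unique, unknown or untested is made for them only; others in the source may bear on it.

Compound 2, `O=C(CCCCC[S+]([O-])c1ccccc1)NO`, is a hydroxamic acid whose chain ends in a sulfoxide joined to an aromatic ring. In a functional assay on CCRF-CEM cells (Homo sapiens) for inhibition (a higher number here means a weaker inhibitor, a lower number a stronger inhibitor), compound 2 gives only a limit, > 25000 nM, and no number. Compound 1, `O=C(CCCCCSc1ccccc1)NO`, which carries a sulfide in place of that sulfoxide, likewise gives only a limit in this assay, > 25000 nM. Both stand at the limit of > 25000 nM in this assay, at which 2 of the 3 values shown sit. Within the data shown here, the single measured number comes from compound 3, `O=C(/C=C/C=C/CSc1cccc2ccccc12)NO`, built on a different ring and an unsaturated chain; in this assay compound 3 gives 1700 nM. Among the measured compounds shown here, no single step links it to compound 2, so the two values show only that another chain and ring reach a measurable number where compound 2 does not.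

Compound 4, `O=C(CCCCC[S+]([O-])c1ccc(Cl)cc1)NO`, differs from compound 2 by chloro in place of hydrogen on an aromatic carbon. For the measured compounds named here, no measured pair tests a chloro on this ring, so no step size is known from the data. The expected change is a number no higher from compound 2 to compound 4 (the limit leaves the size open), none beyond the scatter, because compound 2 already sits at the limit of > 25000 nM in this assay, at which 2 of the 3 values shown sit. Compound 4 is therefore estimated at 25000 nM, between 8000 nM and 60000 nM, with a strong chance that only a limit is reported once more.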

Compound 4, half-maximal inhibitory concentration: 2600 nM
Compound 4: middle estimate off by 9.6-fold (0.98 log units), on the high side; the whole stated range lies above it.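

Chloro in place of hydrogen on an aromatic carbon, para to a large group, is the first single change here that brings a compound off the limit: in this assay it gives an at least 9.6-fold lower number from compound 2 to compound 4 (0.98 log units; beyond the scatter). The ring of compound 2 therefore has a position where one added chlorine atom turns a limit into a measured number, without any change to the sulfoxide chain. The size of this step is only a minimum, because compound 2 gives a limit and no number: the limit of > 25000 nM in this assay, at which 2 of the 4 values shown sit.

As far as these compounds go, whether fluoro, methoxy or an amine at this same place would also lower the number remains open, as does the effect of a chloro elsewhere on the ring. From the compounds shown here alone, it is also open whether chloro would have a similar effect on the sulfide of compound 1.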